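A few compounds are considered here, and "the series" means these few. Any claim that something is new, unique, unknown or untested is made for them only; others in the source may bear on it.

In a functional assay on MCF7 cells (Homo sapiens) for cytotoxicity, read by sulforhodamine B assay, with a stated time of 48 h (on this read-out higher numbers stand for weaker inhibition of growth and lower numbers for stronger inhibition of growth), three compounds have been measured so far:
Compound 1 `O=C1C(=O)N(CN2CCN(c3ccnc4cc(Cl)ccc34)CC2)c2cc(Cl)ccc21` gives 26100 nM.
Compound 2 `O=C1C(=O)N(CN2CCN(c3ccnc4cc(Cl)ccc34)CC2)c2cc(Br)ccc21` gives 17600 nM.
Compound 3 `NC(=S)N/N=C1/C(=O)N(CN2CCN(c3ccnc4cc(Cl)ccc34)CC2)c2cc(Cl)ccc21` gives 22500 nM.

Compounds 1 and 2 share one core, compound 3 carries another; the difference between the two cores is not broken down here. From compound 1 to compound 2 the change is bromo in place of chloro on an aromatic carbon, and it made a 1.5-fold lower number from compound 1 to compound 2 (0.17 log units; within the scatter). Compound 4 `NC(=S)N/N=C1/C(=O)N(CN2CCN(c3ccnc4cc(Cl)ccc34)CC2)c2cc(Br)ccc21` has not yet been measured; from compound 3 to compound 4 the change is bromo in place of chloro on an aromatic carbon, the same change at the same place. Because a 1.5-fold lower number from compound 1 to compound 2 (0.17 log units; within the scatter) lay within the scatter, the step expected for compound 4 is a 1.4-fold lower number from compound 3 to compound 4 (0.15 log units; within the scatter), a shift of the same modest size applied to compound 3 and its 22500 nM. Compound 4 is therefore estimated at 16000 nM in this assay, with a likely range from 8000 nM to 35000 nM.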

Compound 4, concentration for 50% growth inhibition: 11400 nM
Compound 4: middle estimate off by 1.4-fold (0.15 log units), on the high side, within the range that was stated.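

In this assay bromo in place of chloro on the aromatic carbon gave a 2.0-fold lower number from compound 3 to compound 4 (0.30 log units; within the scatter) and the two cores did not tell apart: the same change on two cores in this assay, a 1.5-fold lower number (0.17 log units; within the scatter) from compound 1 to compound 2 and a 2.0-fold lower number (0.30 log units; within the scatter) from compound 3 to compound 4, 1.3-fold (0.12 log units) apart, within the scatter of two such steps. On these two cores, then, the change carried over with no difference that could be told from the scatter. It does not show that the change has a real effect on either core, as each step lies within the scatter, and two cores cannot speak for others in the series.

The compounds shown leave open how fluoro, methyl or an amine on that aromatic carbon would read in this assay. They also leave open whether a group other than bromo would carry over between the two cores in the same way.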